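A few compounds are considered here, and "the series" means these few. Any claim that something is new, unique, unknown or untested is made for them only; others in the source may bear on it.

Working notes on the hydroxamic acid series.

Of the compounds shown here, three sharing the same core have been measured. Compound 1 `O=C(NCc1ccc2cc(C(=O)NO)sc2c1)c1cccnc1` carries an amide on a methylene linker; in a functional assay on HCT-116 cells (Homo sapiens) for cytotoxicity, read by resazurin assay, with a stated time of 5 days (on this read-out lower numbers stand for stronger inhibition and higher numbers for weaker inhibition), compound 1 gives 730 nM. Compound 2 `N[C@@H](CCc1ccccc1)C(=O)Nc1ccc2cc(C(=O)NO)sc2c1` carries an amino acid-derived amide directly on the core, and in this assay compound 2 gives 3400 nM. Compound 3 `CN(C)CCCC(=O)Nc1ccc2cc(C(=O)NO)sc2c1` carries a dimethylamino-bearing chain amide on the core; in this assay compound 3 gives 2400 nM. Compound 1 has the lowest number of the three. The nearest number is that of compound 3, already beyond the scatter, and the furthest is that of compound 2, also beyond the scatter, so compound 1 stands as the most potent of the measured set.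

Compound 4 `O=C(NCc1ccc2cc(C(=O)NO)sc2c1)c1ccco1` has not yet been measured. It differs from compound 1 in one place: furan-2-yl in place of pyridin-3-yl on a carbonyl carbon. The amide on the methylene linker is kept; only the aromatic group on the carbonyl carbon changes. Among the measured compounds shown here, no measured pair shows this kind of exchange, so there is nothing to anchor a direction. The expectation is a step in this assay that stays within the scatter, in either direction, from compound 1 to compound 4; a step of a 1.2-fold higher number from compound 1 to compound 4 (0.09 log units; within the scatter) is estimated. Compound 4 is accordingly expected to give about 900 nM, with a range of 400 nM to 2000 nM.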

Compound 4, half-maximal inhibitory concentration: 70 nM
Compound 4: the middle estimate sits 13-fold (1.11 log units) above what was measured; the whole stated range lies above it.
By their numbers in this assay, from the lowest: compound 4; then compound 1; then compounds 3 and 2 (each within the scatter of the next).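

The aromatic group on the carbonyl carbon of the amide on the methylene linker turns out to be a sensitive place: in this assay furan-2-yl in place of pyridin-3-yl gives a 10-fold lower number from compound 1 to compound 4 (1.02 log units; beyond the scatter) and so counts as a large step. Both groups are single aromatic rings with one hetero atom, no hydrogen-bond donors, one hydrogen-bond acceptor and no net charge, so these counts do not separate them; what differs is the ring size and the hetero atom, oxygen in place of nitrogen. No data at hand account for the size of this step.

The compounds shown do not tell whether the step belongs to furan-2-yl in particular or extends to other groups at this place, such as thiophen-2-yl, phenyl or pyridin-2-yl, which would separate the effect of ring size from that of the hetero atom. Going by these compounds, it also remains open whether furan-2-yl would bring a similar step on a core without the methylene linker, where the amide nitrogen sits directly on the core as in compound 2 and compound 3.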